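Cytotoxicity of an aryloxy anilinoquinazoline pair, next variant

This account rests on a few compounds, and the source may have more. Where it says the series, first, only, none or still open, it means among the compounds named here.

Two compounds of the series have a number in an ADME assay on MT4 cells (Homo sapiens) for cytotoxicity, read by MTT assay, with a stated time of 4 days (a lower number here means that less compound is tolerated, a higher number that more compound is tolerated), so far. Compound 1 `COc1ccc(Oc2nc(Nc3ccc(C#N)cc3)nc3ccccc23)cc1` gives 340000 nM in this assay. Compound 2 `COc1cc(C#N)cc(Cl)c1Oc1nc(Nc2ccc(C#N)cc2)nc2ccccc12` gives 220000 nM, and the two values lie within the scatter of each other, so no order between them is claimed. Compound 3 `N#Cc1ccc(Nc2nc(Oc3ccc(Br)cc3)c3ccccc3n2)cc1` carries bromo in place of methoxy on an aromatic carbon relative to compound 1. Among the measured compounds shown here, no step of this kind has been measured, so the expectation for a 1.4-fold lower number from compound 1 to compound 3 (0.13 log units; within the scatter) is no change beyond the scatter. Compound 3 is estimated at 250000 nM in this assay, with a range from 120000 nM to 500000 nM.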

Compound 3, half-maximal cytotoxic concentration: 215000 nM
Beside the measured number, compound 3's estimate is 1.2-fold (0.07 log units) above it; measured number inside the range.
By their numbers in this assay, from the lowest: compounds 3, 2 and 1 (each within the scatter of the next).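

In this assay, going from 4-methoxyphenoxy to 4-bromophenoxy gives a 1.6-fold lower number from compound 1 to compound 3 (0.20 log units; within the scatter). Among the compounds shown here, this is the first one-place step, and at this place, para to a large group, methoxy and bromo cannot be told apart in this read-out. No available evidence bears on this result. From the compounds shown here alone, it remains open whether an amine, a carboxylic acid or a longer chain at this place would move the number beyond the scatter. Going by these compounds, the effect of changes elsewhere on the shared core also remains open.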